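Thiourea in place of benzyl on the ring nitrogen

This account rests on a few compounds, and the source may have more. Where it says the series, first, only, none or still open, it means among the compounds named here.

Compound 1, `N#Cc1ccccc1CN1CCc2c(sc(NC(=O)c3ccccc3Cl)c2C(N)=O)C1`, gives 9500 nM in a functional assay on MKN-74 cells (Homo sapiens) for antiproliferative activity, with a stated time of 24 h; on this read-out higher numbers stand for weaker inhibition and lower numbers for stronger inhibition.
Compound 2, `Cc1ccc(C(=O)Nc2sc3c(c2C(N)=O)CCN(Cc2ccc(Cl)cc2Cl)C3)cc1`, gives 25500 nM in this assay.
Compound 3, `NC(=O)c1c(NC(=O)c2ccccc2F)sc2c1CCN(Cc1ccc(Cl)cc1Cl)C2`, gives 9610 nM in this assay.

Of the compounds shown here, three share a core and have been measured. Compound 1 has the lowest number of the three, but compound 3 sits at the same level within the scatter, so no order between those two can be stated; compound 2 lies beyond the scatter from both. Among the compounds with values here, the one single-point step among them, a 2.7-fold lower number from compound 2 to compound 3 (0.42 log units; beyond the scatter), concerns the group on the carbonyl carbon and is modest.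

Compound 4, `NC(=O)c1c(NC(=O)c2ccccc2Cl)sc2c1CCN(C(=S)Nc1ccccc1I)C2`, has not been measured. It differs from compound 1 in this way: a group of 10 heavy atoms (7 carbon, 1 nitrogen, 1 sulfur, 1 iodine; one six-membered aromatic ring of carbon only) in place of a group of 9 heavy atoms (8 carbon, 1 nitrogen; one six-membered aromatic ring of carbon only), on an amine nitrogen in a ring. Within the data shown here, the change sits on an amine nitrogen in a ring, a place that no measured step touches; the only recorded step concerns a different part of the molecule and so offers no guide to the size or direction of this one. With nothing to lean on, the step from compound 1 to compound 4 in this assay is expected to stay near zero, a 1.1-fold higher number from compound 1 to compound 4 (0.02 log units; within the scatter), with a wide range of uncertainty. Compound 4 is therefore estimated at 10000 nM, between 3000 nM and 40000 nM.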

Compound 4, half-maximal inhibitory concentration: 2630 nM
For compound 4 the middle estimate is 3.8-fold (0.58 log units) above the measured one; measured number below the stated range.
By their numbers in this assay, from the lowest: compound 4; then compounds 1 and 3 (each within the scatter of the next); then compound 2.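

In this assay the amine nitrogen in a ring proves open to change, and exchanging 2-cyanobenzyl for the group carrying sulfur and iodine gives a 3.6-fold lower number from compound 1 to compound 4 (0.56 log units; beyond the scatter) on this read-out. This first measured step at the position shows that a benzyl group is not needed there for antiproliferative activity at this level: the entering group keeps a six-membered aromatic ring of carbon only, yet it loses the triple bond and brings a double bond outside aromatic rings and a hydrogen-bond donor. No measurement at hand explains why the number falls.

The sulfur, the iodine and the added hydrogen-bond donor all enter together in this single step, so the compounds shown cannot say which of them, if any, accounts for the lower number, nor whether the step would hold with another group on the carbonyl carbon. From the compounds shown here alone, it also remains open how the read-out would respond to a urea with oxygen in place of the sulfur, to a plain phenyl thiourea without iodine, or to a longer chain between the thiourea and the aromatic ring.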